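Pyrrole for thiazole on a shared amide core

The source may report more compounds than this note shows. Statements on the series, on what has been measured and on what is new or still open speak of the compounds shown alone.

The series rests on a shared core carrying a five-membered aromatic ring on the aniline. Compound 1 `O=C(Nc1ccc(-c2cscn2)cc1)[C@@H]1CCCN(Cc2ccc(F)c(F)c2)C1` gives 4000 nM in a functional assay on A-375 cells (Homo sapiens) for activation, with a stated time of 3 days (on this read-out lower numbers stand for an effect already at smaller amounts and higher numbers for an effect only at larger amounts of compound), compound 2 `O=C(Nc1ccc(-c2cscn2)cc1)C1CCCN(Cc2cc(F)c(F)c(F)c2)C1` gives 1260 nM in this assay, and compound 3 `O=C(Nc1ccc(-c2nccs2)cc1)C1CCCN(Cc2ccc(F)c(F)c2)C1` gives 800 nM in this assay. Compound 3 stands at the low end of the three numbers shown: its distance to compound 2 lies within the scatter, while its distance to compound 1 lies beyond it.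

Compound 4 `O=C(Nc1ccc(-c2ccc[nH]2)cc1)C1CCCN(Cc2ccc(F)c(F)c2)C1` has not been measured. It differs from compound 3 in one place: 1H-pyrrol-2-yl in place of 1,3-thiazol-2-yl on an aromatic carbon. Going by the values given here, no measured pair shows this exchange, so its size is unknown here. Among the compounds with values here, a modest step towards higher numbers is expected, in line with compound 3 at 800 nM being the only member carrying the ring that leaves. The step from compound 3 to compound 4 is estimated at a 2.0-fold higher number from compound 3 to compound 4 (0.30 log units; within the scatter) in this assay. Compound 4 is expected to give about 1600 nM in this assay, most likely between 450 nM and 6000 nM.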

Compound 4, half-maximal effective concentration: 720 nM
Compound 4: the middle estimate sits 2.2-fold (0.35 log units) above what was measured; the range from low to high includes it.
By their numbers in this assay, from the lowest: compounds 4, 3 and 2 (each within the scatter of the next); then compound 1.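

Placing 1H-pyrrol-2-yl in place of 1,3-thiazol-2-yl on this aromatic carbon, para to a large group, gives a 1.1-fold lower number from compound 3 to compound 4 (0.05 log units; within the scatter) in this assay. The read-out therefore does not separate the two five-membered rings, even though the ring that enters has 1 hydrogen-bond donor and 0 hydrogen-bond acceptors, while the ring that leaves has 0 donors, 2 acceptors and a sulfur atom. No measurement shown here accounts for how close the two values lie.

From the compounds shown here alone, it remains open whether a methyl group on the nitrogen of the 1H-pyrrol-2-yl ring would keep the value in the same range. Going by these compounds, it is also open whether a furan-2-yl ring, a phenyl ring or a carboxylic acid in this place would do so.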